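The source may report more compounds than this note shows. Statements on the series, on what has been measured and on what is new or still open speak of the compounds shown alone.

Compound 1 `CNC1=C(Sc2ccccc2)C(=O)c2ncccc2C1=O` is tested in a functional assay on cells (Neutrophil, Homo sapiens) for inhibition, read by WST assay, with a stated time of 20 min; a higher number here means a weaker inhibitor, a lower number a stronger inhibitor. In this assay compound 1 gives > 150000 nM, which is a limit of the assay, as the limit of > 150000 nM in this assay, at which 1 of the 3 values shown sits, records. Compound 2 `CNC1=C([S+](C)[O-])C(=O)c2ncccc2C1=O` carries a group of 3 heavy atoms (1 carbon, 1 oxygen, 1 sulfur; no ring) in place of a group of 7 heavy atoms (6 carbon, 1 sulfur; one six-membered aromatic ring of carbon only), on a double-bonded ring carbon. In this assay compound 2 gives > 200000 nM, again a limit of the assay, as the limit of > 200000 nM in this assay, at which 1 of the 3 values shown sits, records. The step that the two limits leave unreadable from compound 1 to compound 2 therefore cannot be sized from these two compounds.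

Compound 3 `CNC1=C(Sc2ccccc2)C(=O)c2cccnc2C1=O` is built on a different core; the difference between the two cores is not broken down here. In this assay, within the data shown here, compound 3 gives 92800 nM, the only number among the three values.

Compound 4 `CNC1=C([S+](C)[O-])C(=O)c2cccnc2C1=O` has not yet been measured. It differs from compound 3 by a group of 3 heavy atoms (1 carbon, 1 oxygen, 1 sulfur; no ring) in place of a group of 7 heavy atoms (6 carbon, 1 sulfur; one six-membered aromatic ring of carbon only), on a double-bonded ring carbon, the same kind of change as from compound 1 to compound 2. Because a step that the two limits leave unreadable from compound 1 to compound 2 is unreadable between two limits, no size is available to carry over, and the step is expected as a 1.6-fold higher number from compound 3 to compound 4 (0.21 log units; within the scatter), resting on compound 3 at 92800 nM. For compound 4 in this assay the expected value is 150000 nM, between 60000 nM and 400000 nM, with a real chance that only a limit is reported.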

Compound 4, half-maximal inhibitory concentration: > 200000 nM
Compound 4: only a limit was reported; the forecaster's own chance of this, stated with the estimate: 60%; middle value at least 1.3-fold (0.12 log units) from the limit.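

On the core of compound 3, putting the smaller sulfur-bearing group in place of phenylsulfanyl gives an at least 2.1-fold higher number from compound 3 to compound 4 (0.33 log units; beyond the scatter) in this assay, and this is a minimum rather than a full size. On the core of compound 1 the same change joins two limits and cannot be read, so it offers no second size to compare, and the compounds show neither that the step carries over between the cores nor that it fails to. What they do show is that the entering group restores no measurable inhibition on either core, with compound 2 and compound 4 resting at the same limit of the assay: the limit of > 200000 nM in this assay, at which 2 of the 4 values shown sit.

As far as these compounds go, what remains open is how this double-bonded ring carbon responds to other groups, such as a primary amine, a carboxylic acid or a longer alkyl chain. From the compounds shown here alone, it is also open whether a different group in place of the methylamino group would give readable numbers on both cores, allowing a true comparison of the step.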